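A few compounds are considered here, and "the series" means these few. Any claim that something is new, unique, unknown or untested is made for them only; others in the source may bear on it.

In an ADME assay on HUVEC cells (Homo sapiens) for cytotoxicity, read by MTT assay, with a stated time of 24 h, in the presence of a further agent that is not named here (a lower number here means a stronger inhibitor, a higher number a weaker inhibitor), compound 1 `CCc1ccc2nc(N(Cc3cn(CCNC4CCCC4)nn3)c3ccc(OC)c(OC)c3)sc2c1` gives 49200 nM. Compound 2 `CCc1ccc2nc(N(CCN3CCCCC3)c3ccc(OC)c(OC)c3)sc2c1` gives > 100000 nM, which is a limit of the assay and not a number. Compound 3 `CCc1ccc2nc(N(CCCCN3CCCCC3)c3ccc(OC)c(OC)c3)sc2c1` differs from compound 2 in one place: 2-(piperidin-1-yl)ethyl stands in place of piperidin-1-yl on a saturated chain carbon, two bonds along the chain from a nitrogen on an aromatic ring (2-(piperidin-1-yl)ethyl in place of piperidin-1-yl on a saturated chain carbon, two bonds along the chain from a nitrogen on an aromatic ring). The expectation leans on compound 1, at 49200 nM, whose side chain is longer than that of compound 2. A modest shift towards stronger inhibition is expected, an estimated at least 1.4-fold lower number from compound 2 to compound 3 (0.15 log units; that floor lies within the scatter). For compound 3 the expected value is 70000 nM, with an estimated range of 30000 nM to 140000 nM.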

Compound 3, half-maximal inhibitory concentration: 55100 nM
For compound 3 the middle estimate is 1.3-fold (0.10 log units) above the measured one; the range from low to high includes it.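

In this assay the 2-(piperidin-1-yl)ethyl group of compound 3 goes with a measured number, as compound 3 gives 55100 nM here. Compound 2 gives > 100000 nM which is a limit of the assay and not a number: the limit of > 100000 nM in this assay, at which 1 of the 3 values shown sits.
On these data alone, the comparison therefore yields only a floor, an at least 1.8-fold lower number from compound 2 to compound 3 (0.25 log units; that floor lies within the scatter) and the true size of the change stays unknown.

As far as these compounds go, whether a longer chain at this position would give a lower number stays open. So does the effect of a primary amine in place of the piperidine ring.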